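Removing one trifluoromethyl from a pyrazole-linked urea

The compounds below may be only part of what the source reports. "The series", "measured", "known", "first", "only" and "open" are said of these compounds alone.

Two compounds built on a shared core carry a urea tail that differs in its aryl end, and both were tested in a functional assay on Malme-3M cells (Homo sapiens) for inhibition, read by sulforhodamine B assay, with a stated time of 48 h, tested at 1 uM; on this read-out lower numbers stand for a stronger effect and higher numbers for a weaker effect at the one concentration tested. Compound 1 `O=C(Nc1cccc(-n2cc(-c3ccncc3)c(-c3cc(O)cc(Cl)c3)n2)c1)Nc1ccc(Cl)c(Cl)c1` gives 76%. Compound 2 `COc1cc(Cl)cc(-c2nn(-c3cccc(NC(=O)Nc4cc(C(F)(F)F)cc(C(F)(F)F)c4)c3)cc2-c2ccncc2)c1` gives 36%, the lower of the two numbers and therefore the stronger effect; the gap between compound 1 and compound 2 lies beyond the usual scatter of this measurement.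

Compound 3 `COc1cc(Cl)cc(-c2nn(-c3cccc(NC(=O)Nc4cccc(C(F)(F)F)c4)c3)cc2-c2ccncc2)c1` has not yet been tested. It differs from compound 2 in one place: hydrogen in place of trifluoromethyl on an aromatic carbon. The change is small in atoms, yet it removes part of the aryl end that sets compound 2 apart from compound 1 in this assay.

Within the data shown here, no measured pair separates out the contribution of a single trifluoromethyl group, so the expectation rests on the two numbers alone. Compound 3 is expected to show a somewhat weaker effect than compound 2, with a step of a number 14 percentage points higher from compound 2 to compound 3 (beyond the scatter) in this assay. The estimated activity for compound 3 is 50%, within a range from 30% to 72%.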

Compound 3, a percentage reported as activity, at one concentration (the size of the read-out at that concentration, not a potency): 75%
Beside the measured number, compound 3's estimate is 25 percentage points below it, outside the stated range (above it).
By their numbers in this assay, from the lowest: compound 2; then compounds 3 and 1 (each within the scatter of the next).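

In this assay, hydrogen in place of trifluoromethyl on an aromatic carbon gives a number 39 percentage points higher from compound 2 to compound 3 (beyond the scatter), and this is the first pair shown that differs only in this group. The result makes this carbon on the aryl end of the urea tail a sensitive place: one change here, with the rest of the molecule kept the same, greatly weakens the effect at the single concentration tested, and the trifluoromethyl group that stays in compound 3 does not preserve the effect seen with compound 2. No available evidence explains why removing this group has such a large effect.

The compounds shown leave open whether a different group on this same carbon, such as a methyl, a nitrile or an amine, would keep the stronger effect of compound 2 or behave more like hydrogen. They also leave open whether the same exchange would give a step of similar size if the methoxy group on the other aryl ring of the shared core were replaced by a different group.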